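The compounds below may be only part of what the source reports. "The series", "measured", "known", "first", "only" and "open" are said of these compounds alone.

In a functional assay on NCI-H460 cells (Homo sapiens) for cytotoxicity, read by sulforhodamine B assay, with a stated time of 48 h, tested at 0.01 uM (a lower number here means a stronger effect, a higher number a weaker effect of the compound at the concentration tested), compound 1 `COc1cc(-c2cc(/C=C/C(=O)c3ccc(N)cc3)[nH]n2)cc(OC)c1OC` gives 102%. Among the measured compounds shown here, the only other number so far comes from compound 2 `COc1ccc(-c2cc(/C=C/C(=O)c3ccc(OC)c(OC)c3)[nH]n2)cc1`, which gives 100%, within the usual scatter of compound 1, so the two cannot be told apart. Compound 3 `COc1cc(-c2cc(/C=C/C(=O)c3ccc(Cl)c(Cl)c3)[nH]n2)cc(OC)c1OC` awaits measurement. It differs from compound 1 in one place: 3,4-dichlorophenyl in place of 4-aminophenyl on a carbonyl carbon. For the measured compounds named here, no step between measured compounds exists to size this change. The step expected is a number 3 percentage points lower from compound 1 to compound 3 (within the scatter), none beyond the scatter. Compound 3 is therefore estimated at 99%, with a range from 85% to 108%.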

Compound 3, a percentage reported as activity, at one concentration (the size of the read-out at that concentration, not a potency): 105%
Estimate against measurement, compound 3: 6 percentage points below, within the range that was stated.
By their numbers in this assay, from the lowest: compounds 2, 1 and 3 (each within the scatter of the next).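

In this assay, among the compounds shown here, the first step at this position, a number 3 percentage points higher from compound 1 to compound 3 (within the scatter), replaces 4-aminophenyl with 3,4-dichlorophenyl on the carbonyl carbon. The entering group has no hydrogen-bond donor or acceptor, yet the step stays within the scatter, so compound 1 and compound 3 cannot be told apart at this concentration. No measured evidence explains this result. Going by these compounds, it remains open whether any group on this carbonyl carbon can move the number beyond the scatter. A carboxylic acid on the ring or a morpholine in its place would test this.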